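Aryl change on the chain: compound 3 to compound 4

The source may hold more compounds than are shown below. What is called first, only, known or untested is meant among the compounds shown, and "the series" means these compounds.

Compound 1 `O=C(/C=C\c1cccc(O)c1)N1N=C(c2ccncc2)OC1c1c[nH]c2ccccc12` reaches only the limit of > 30 ug/mL in an ADME assay on HeLa cells (Homo sapiens) for cytotoxicity, read by MTT assay, with a stated time of 72 h (a lower number here means a stronger inhibitor of growth, a higher number a weaker inhibitor of growth), so its value is a limit and not a number. Compound 2 `O=C(/C=C\c1ccc(O)cc1)N1N=C(c2ccncc2)OC1c1c[nH]c2ccccc12` likewise stops at the limit of > 30 ug/mL in this assay. Compound 3 `COc1ccc(/C=C\C(=O)N2N=C(c3ccncc3)OC2c2c[nH]c3ccccc23)cc1` also gives only the limit of > 30 ug/mL in this assay. Because of this the limit of > 30 ug/mL in this assay, at which 3 of the 3 values shown sit, the three steps among them stay unreadable: a step that the two limits leave unreadable from compound 1 to compound 2, a step that the two limits leave unreadable from compound 1 to compound 3 and a step that the two limits leave unreadable from compound 2 to compound 3. Compound 3 therefore stands with the other two at the limit and cannot be ranked against them.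

Compound 4 `O=C(/C=C\c1ccccc1F)N1N=C(c2ccncc2)OC1c1c[nH]c2ccccc12` carries 2-fluorophenyl in place of 4-methoxyphenyl on a double-bonded chain carbon bound to a double-bonded chain carbon. Going by the values given here, none of the measured steps reads as a number, so no size can be taken from them; the three limits show only that exchanges of the aryl group on the chain have not yet brought any compound under the limit. The expected step that the limit leaves unreadable from compound 3 to compound 4 in this assay is thus none beyond the scatter, with compound 4 most probably again at the limit. Compound 4 is estimated at 40 ug/mL in this assay, with a range from 15 ug/mL to 120 ug/mL.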

Compound 4, concentration for 50% growth inhibition: > 30 ug/mL
Compound 4: only a limit was reported; the forecaster's own chance of this, stated with the estimate: 85%; the middle value is on the limit's open side.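

In this assay compound 4 gives > 30 ug/mL as a limit and not a number. Its steps from compound 1, compound 2 and compound 3 therefore cannot be read: the limit of > 30 ug/mL in this assay, at which 4 of the 4 values shown sit. The compounds shown leave open how far each lies past the limit, and whether any aryl group on the chain brings a value under it.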